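From 4-methylphenyl to 4-hydroxyphenyl on a shared core

The source may report more compounds than this note shows. Statements on the series, on what has been measured and on what is new or still open speak of the compounds shown alone.

Compounds measured in a functional assay on A549 cells (Homo sapiens) for inhibition, read by CCK-8 assay, with a stated time of 72 h, tested at 10 uM; on this read-out higher numbers stand for more inhibition of growth at the one concentration tested and lower numbers for less inhibition of growth:
- compound 1 `COC(=O)c1ccc(NC(=O)C2(C(=O)Nc3ccc(Nc4ncc5cc(C(=O)N(C)C)n(C6CCCC6)c5n4)cc3)CC2)cc1`: 92%
- compound 2 `Cc1ccc(NC(=O)C2(C(=O)Nc3ccc(Nc4ncc5cc(C(=O)N(C)C)n(C6CCCC6)c5n4)cc3)CC2)cc1`: 90.6%

For the measured compounds named here, compound 2, at 90.6%, stands within the scatter of compound 1, the only other compound measured so far. The next structure is compound 3 `CN(C)C(=O)c1cc2cnc(Nc3ccc(NC(=O)C4(C(=O)Nc5ccc(O)cc5)CC4)cc3)nc2n1C1CCCC1`, which carries hydroxy in place of methyl on an aromatic carbon. The change lies on a six-membered aromatic ring of carbon only, para to a large group, and turns 4-methylphenyl into 4-hydroxyphenyl.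

Going by the values given here, one measured step bears on this change, also a swap on an aromatic carbon: a number 1.4 percentage points lower from compound 1 to compound 2 (within the scatter), with methyl in place of methoxycarbonyl. It is a single step, and neither measured compound carries hydroxy, so the data give no direct measure of this group. Resting on compound 2 at 90.6% and on that one step, no shift beyond the scatter is expected in this assay. The estimated change is a number 3.6 percentage points lower from compound 2 to compound 3 (within the scatter). Compound 3 is estimated at 87%, with an expected range from 72% to 96%.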

Compound 3, percent growth inhibition at one concentration: 94.4%
Compound 3: the middle estimate sits 7.4 percentage points below what was measured; the range from low to high includes it.
By their numbers in this assay, from the lowest: compounds 2, 1 and 3 (each within the scatter of the next).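

In this assay, the swap of methyl for hydroxy gives a number 3.8 percentage points higher from compound 2 to compound 3 (within the scatter), and the swap of methoxycarbonyl for hydroxy gives a number 2.4 percentage points higher from compound 1 to compound 3 (within the scatter). This position, on a six-membered aromatic ring of carbon only and para to a large group, has now carried methoxycarbonyl, methyl and hydroxy, and this read-out separates none of the three, even though hydroxy adds a hydrogen-bond donor and a hydrogen-bond acceptor that methyl does not have. Nothing available here accounts for the numbers staying this close across the three groups.

From the compounds shown here alone, whether an amine, a carboxylic acid or a longer chain on this same aromatic carbon would also stay within the scatter of compound 3 remains open, as does whether hydroxy would behave the same way elsewhere on the ring. With only one concentration tested, the compounds shown also leave open whether these three groups would still read alike at other concentrations or in other cell lines.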